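The source may hold more compounds than are shown below. What is called first, only, known or untested is meant among the compounds shown, and "the series" means these compounds.

Measured compounds:
Compound 1, `Cc1c(C)c2c(c(C)c1O)CC[C@@](C)(CC(=O)O)O2`: 17000 nM
Compound 2, `CCCCCCCCCCCCCCCCCCOC1=C(O)[C@@H](C(O)CO)OC1=O`: 6000 nM

Two compounds have been run in a functional assay (brain) for inhibition, with Rattus norvegicus as the target (on this read-out higher numbers stand for weaker inhibition and lower numbers for stronger inhibition), so far. Compound 1, with structure `Cc1c(C)c2c(c(C)c1O)CC[C@@](C)(CC(=O)O)O2`, gives 17000 nM in this assay, the higher of the two numbers and therefore the weaker inhibition. Compound 2, with structure `CCCCCCCCCCCCCCCCCCOC1=C(O)[C@@H](C(O)CO)OC1=O`, gives 6000 nM in this assay, a lower number that lies beyond the usual scatter from the value of compound 1. The two structures share little, so their gap says nothing about any single change.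

Compound 3, with structure `Cc1c(C)c2c(c(C)c1O)CC[C@@](C)(CC[S+](C)C)O2`, has not yet been measured. It is built on the core of compound 1 and differs from it in one place: a group of 4 heavy atoms (3 carbon, 1 sulfur; no ring) in place of a group of 3 heavy atoms (1 carbon, 2 oxygen; no ring), on a saturated chain carbon bound to a saturated ring carbon. For the measured compounds named here, no step between measured compounds covers a change of this kind, so there is no direct guide to its size or direction. A move away from the charged acid toward a charged sulfur group could go either way, and a step of modest size, within or just beyond the scatter, is expected, a 1.7-fold lower number from compound 1 to compound 3 (0.23 log units; within the scatter). For compound 3 the estimated value in this assay is 10000 nM, with a likely range from 2000 nM to 50000 nM.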

Compound 3, half-maximal inhibitory concentration: 2000 nM
Estimate against measurement, compound 3: 5.0-fold (0.70 log units) above; low and high end bracket the measured number.
By their numbers in this assay, from the lowest: compound 3; then compound 2; then compound 1.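

In this assay, putting the sulfur-bearing group in place of the carboxy group, on a saturated chain carbon bound to a saturated ring carbon, gives an 8.5-fold lower number from compound 1 to compound 3 (0.93 log units; beyond the scatter). For the compounds shown here, this is the first sign that what stands at this position on the shared core can move the number well beyond the scatter, and compound 3 shows that the carboxy group is not needed for inhibition to be seen. The change alters several things together, from no net charge to a net charge of +1 and from one hydrogen-bond donor and one acceptor to none of either, and nothing measured here shows which of these differences accounts for the step.

Still open, going by these compounds, is whether the sulfur atom itself, the positive charge or the loss of the carboxy group matters most, as a single step cannot pull these apart. An uncharged thioether at this position would test the sulfur without the charge, while a trimethylammonium group would test a positive charge without the sulfur.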